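Nitro for bromo on the shared core of compound 3

The compounds below may be only part of what the source reports. "The series", "measured", "known", "first", "only" and "open" are said of these compounds alone.

Compound 1 `Fc1ccc(C2(c3ccc(F)cc3)CNC(c3cccc(Cl)c3)=N2)cc1` carries chloro on a six-membered aromatic ring of carbon only and in an assay on LM cells for displacement of a labelled ligand from Neuropeptide Y receptor type 5 (Homo sapiens) (a lower number here means a stronger inhibitor, a higher number a weaker inhibitor), compound 1 gives 5.4 nM. Compound 2 `Fc1ccc(C2(c3ccc(F)cc3)CNC(c3cccc(C(F)(F)F)c3)=N2)cc1` carries trifluoromethyl at that place; in this assay compound 2 gives 6.2 nM. Compound 3 `Fc1ccc(C2(c3ccc(F)cc3)CNC(c3cccc(Br)c3)=N2)cc1` carries bromo there, and in this assay compound 3 gives 4.8 nM. The steps among the three are all small: a 1.1-fold higher number from compound 1 to compound 2 (0.06 log units; within the scatter), a 1.1-fold lower number from compound 1 to compound 3 (0.05 log units; within the scatter) and a 1.3-fold lower number from compound 2 to compound 3 (0.11 log units; within the scatter). Compound 3 holds the lowest of the three numbers, but its gaps to compound 1 and compound 2 stay within the scatter, so no ranking follows.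

Compound 4 `O=[N+]([O-])c1cccc(C2=NC(c3ccc(F)cc3)(c3ccc(F)cc3)CN2)c1` differs from compound 3 by nitro in place of bromo on an aromatic carbon, that is 3-bromophenyl to 3-nitrophenyl. For the measured compounds named here, the only bearing evidence is that the three measured exchanges at this place all stayed within the scatter; nothing measured covers nitro. The expected step is a 1.7-fold higher number from compound 3 to compound 4 (0.22 log units; within the scatter), with a wider range than the scatter alone. Compound 4 is estimated at 8 nM in this assay, between 3 nM and 25 nM.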

Compound 4, half-maximal inhibitory concentration: 4.3 nM
For compound 4 the middle estimate is 1.9-fold (0.27 log units) above the measured one, within the range that was stated.
By their numbers in this assay, from the lowest: compounds 4, 3, 1 and 2 (each within the scatter of the next).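

Nitro, with its count of 3 heavy atoms and 2 hydrogen-bond acceptors, replaces single-atom bromo at this place without the number in this assay leaving the scatter (a 1.1-fold lower number from compound 3 to compound 4 (0.05 log units; within the scatter)). The same holds against the other two groups (a 1.3-fold lower number from compound 1 to compound 4 (0.10 log units; within the scatter); a 1.4-fold lower number from compound 2 to compound 4 (0.16 log units; within the scatter)), so all four groups on this aromatic carbon, meta to a large group, remain unranked, and a group bearing hydrogen-bond acceptors now sits alongside the halogens and trifluoromethyl with no separation among compounds 1 to 4. Nothing available explains this flatness.

As far as these compounds go, whether an amine, a carboxylic acid or a longer chain at this place would give a step beyond the scatter remains open. Also open is whether the flatness among these four compounds extends to any group outside them.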